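Inverting two ring stereocentres in compound 2

This account rests on a few compounds, and the source may have more. Where it says the series, first, only, none or still open, it means among the compounds named here.

Compound 2 `O=C(O)[C@@H]1NC[C@@H](O)[C@@H](O)[C@@H]1O` stands lowest of the two compounds measured in an assay for inhibition of alpha-N-acetylgalactosaminidase (Gallus gallus), tested at 1000 uM; a higher number here means more inhibition at the concentration tested (going by the name of the read-out), a lower number less inhibition: compound 2 gives 7.2%, while its mirror image, compound 1 `O=C(O)[C@H]1NC[C@H](O)[C@H](O)[C@H]1O`, gives 21%. For the measured compounds named here, the only measured step is a number 13.8 percentage points lower from compound 1 to compound 2 (beyond the scatter), and it rests solely on (the fact that compounds 1 and 2 differ only in the configuration as drawn). Compound 3 `O=C(O)[C@@H]1NC[C@H](O)[C@@H](O)[C@H]1O` has not yet been measured. It differs from compound 2 as follows: the two compounds have the same atoms and bonds and differ only in configuration as drawn: 2 of 4 stereo elements differ; a stereocentre at a saturated ring carbon is drawn R in compound 2 and S in compound 3; a stereocentre at a saturated ring carbon is drawn R in compound 2 and S in compound 3. Going by the values given here, no measured step covers a change in which only part of the stereocentres is inverted; the single step available concerns the complete inversion of all four. The size of a number 13.8 percentage points lower from compound 1 to compound 2 (beyond the scatter) sets the scale of what configuration alone can do in this set, so a step of about that magnitude in either direction, or none beyond the scatter, is possible. Compound 3 is therefore expected to give 14% (range 0% to 35%). The expected step is a number 6.8 percentage points higher from compound 2 to compound 3 (within the scatter).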

Compound 3, a percentage reported as inhibition, at one concentration (the size of the read-out at that concentration, not a potency): 4%
The estimate for compound 3 lay 10 percentage points above the measured number, within the range that was stated.
By their numbers in this assay, from the lowest: compounds 3 and 2 (each within the scatter of the next); then compound 1.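

Inverting two of the four ring stereocentres can leave the read-out in this assay without a change beyond the scatter: a number 3.2 percentage points lower from compound 2 to compound 3 (within the scatter). A two-centre inversion starting from compound 1 does open a gap beyond the scatter, so the full mirror-image change is not needed for one: a number 17 percentage points lower from compound 1 to compound 3 (beyond the scatter). Configuration is the only difference in that pair: the fact that compounds 1 and 3 differ only in the configuration as drawn

Because each inversion here involves two or four centres together, the contribution of any single stereocentre remains unresolved. Also open, going by these compounds, is how the core of compound 1 would read in this assay with a hydroxymethyl group or a methyl ester in place of the carboxylic acid.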